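A few compounds are considered here, and "the series" means these few. Any claim that something is new, unique, unknown or untested is made for them only; others in the source may bear on it.

Compound 1 `c1ccc(CNCC2CCN(CCCc3c[nH]c4ccc(-n5cnnc5)cc34)CC2)cc1` and compound 2 `CC(=O)Nc1ccc([C@H](C)NCC2CCN(CCCc3c[nH]c4ccc(-n5cnnc5)cc34)CC2)cc1` share a common core and have both been measured in an assay on CHO cells for displacement of a labelled ligand from 5-hydroxytryptamine receptor 1B (Homo sapiens); on this read-out higher numbers stand for weaker inhibition and lower numbers for stronger inhibition. Compound 1 gives 28 nM in this assay, the higher of the two numbers, while compound 2 gives 9.3 nM; the step of a 3.0-fold lower number from compound 1 to compound 2 (0.48 log units; beyond the scatter) follows from an exchange on the amine nitrogen. Compound 3 `CN(Cc1ccsc1)C1CCN(CCCc2c[nH]c3ccc(-n4cnnc4)cc23)CC1` has not yet been measured. Compared with compound 1 it carries a different change, (methyl((thiophen-3-yl)methyl)amino in place of (benzylamino)methyl on a saturated ring carbon), which removes the hydrogen-bond donor and alters both the ring and the spacing to the saturated ring. Among the measured compounds shown here, no measured step addresses this kind of change; the step from compound 1 to compound 2 concerns another substituent and offers only a loose guide, showing that this position tolerates modification. Compound 3 is therefore expected to stay close to compound 1, with an estimated step of a 1.1-fold higher number from compound 1 to compound 3 (0.03 log units; within the scatter) that may not exceed the scatter. In this assay compound 3 is estimated at 30 nM, within a range from 8 nM to 110 nM.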

Compound 3, half-maximal inhibitory concentration: 35 nM
Compound 3: the middle estimate sits 1.2-fold (0.07 log units) below what was measured, and the stated range covers the measured number.
By their numbers in this assay, from the lowest: compound 2; then compounds 1 and 3 (each within the scatter of the next).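

In this assay the exchange gives a 1.3-fold higher number from compound 1 to compound 3 (0.10 log units; within the scatter) and so shows that this saturated ring carbon accepts methyl((thiophen-3-yl)methyl)amino in place of (benzylamino)methyl with no readable shift in the number. The earlier step concerned only a substituent on the amine nitrogen, whereas this one changes the aromatic ring, from a six-membered ring of carbon only to a five-membered ring with 1 hetero atom, and takes the count of hydrogen-bond donors in the group from 1 to 0. No evidence available accounts for this result.

Going by these compounds, because these changes arrive together, their separate contributions remain open. On these data alone, it is also open how a pyridine ring or a furan ring would read in place of the thiophene ring, or how an ethyl group would read in place of the methyl on this amine.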